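Adding an azido group to the shortest amide

The compounds below may be only part of what the source reports. "The series", "measured", "known", "first", "only" and "open" are said of these compounds alone.

Measured so far:
Compound 1, `CCC/C=C/C(=O)N(Cc1ccc(OC)c(O)c1)c1cc(OC)c(OC)c(OC)c1`, 57 nM
Compound 2, `CCC(=O)N(Cc1ccc(OC)c(O)c1)c1cc(OC)c(OC)c(OC)c1`, 98 nM
Compound 3, `COc1ccc(CN(C(C)=O)c2cc(OC)c(OC)c(OC)c2)cc1O`, 160 nM

All three share one core and differ only in the group on the carbonyl carbon of the amide. In a functional assay on KYSE-450 cells (Homo sapiens) for inhibition, read by MTT assay, with a stated time of 48 h (on this read-out lower numbers stand for stronger inhibition and higher numbers for weaker inhibition), compound 3 gives the highest of the three numbers: a 2.8-fold higher number from compound 1 to compound 3 (0.45 log units; beyond the scatter), while a 1.6-fold higher number from compound 2 to compound 3 (0.21 log units; within the scatter).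

Compound 4, `COc1ccc(CN(C(=O)CN=[N+]=[N-])c2cc(OC)c(OC)c(OC)c2)cc1O`, has not yet been measured. It differs from compound 3 by azido in place of hydrogen on a saturated chain carbon bound to a carbonyl carbon; read one bond further out, the acetyl becomes an (azidomethyl)carbonyl.

Among the compounds with values here, two measured steps bear on this change, both touching the same end of the amide. a 1.6-fold higher number from compound 2 to compound 3 (0.21 log units; within the scatter), so adding one carbon at that position shifted little. a 2.8-fold higher number from compound 1 to compound 3 (0.45 log units; beyond the scatter), a modest gain with the longer pent-1-en-1-yl chain. Nothing measured shows an azido group, so the direction is open. Compound 4 is therefore expected to sit near compound 3, with a 1.3-fold lower number from compound 3 to compound 4 (0.12 log units; within the scatter), and its estimated value in this assay is 120 nM, within 50 nM to 350 nM.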

Compound 4, half-maximal inhibitory concentration: 160 nM
The estimate for compound 4 lay 1.3-fold (0.12 log units) below the measured number, within the range that was stated.
By their numbers in this assay, from the lowest: compounds 1, 2, 3 and 4 (each within the scatter of the next, the first and the last beyond it).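

In this assay, azido in place of hydrogen on a saturated chain carbon bound to a carbonyl carbon leaves the number where it stood (no change at the digits printed from compound 3 to compound 4 (within the scatter)), so this position accepts a group of several nitrogen atoms with no shift in the read-out. Azido in place of methyl also stays close (a 1.6-fold higher number from compound 2 to compound 4 (0.21 log units; within the scatter)), while azidomethyl in place of pent-1-en-1-yl gives a modest gap (a 2.8-fold higher number from compound 1 to compound 4 (0.45 log units; beyond the scatter)), so among these four compounds the only steps beyond the scatter are those that start from the pent-1-en-1-yl chain of compound 1. Nothing available explains why the azido group leaves the number unchanged.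

An amine or a carboxylic acid on this same chain carbon remains an open case. So does a longer saturated chain, such as pentyl, which would test whether the double bond of compound 1 matters or the chain length alone.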